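Amide nitrogen variation: from compound 3 to compound 4

The source may report more compounds than this note shows. Statements on the series, on what has been measured and on what is new or still open speak of the compounds shown alone.

Compound 3 `CC(C)=CCCC1=CC[C@@H](C(N)=O)[C@H](c2ccccc2)C1` carries an unsubstituted amide on the shared core. In an assay on isolated protein for inhibition of Apoptosis regulator Bcl-2 (Homo sapiens), read by fluorescence polarization, with stated times of 5 min and 10 min (a lower number here means a stronger inhibitor, a higher number a weaker inhibitor), compound 3 gives > 23000 nM, which is a limit of the assay and not a number. Compound 1 `COc1ccc(NC(=O)[C@@H]2CC=C(CCC=C(C)C)C[C@H]2c2ccccc2)cc1` carries 4-methoxyphenyl on the amide nitrogen; in this assay compound 1 gives > 23000 nM, again a limit. Compound 2 `COC(=O)CCNC(=O)[C@@H]1CC=C(CCC=C(C)C)C[C@H]1c1ccccc1` carries 2-(methoxycarbonyl)ethyl on that nitrogen; in this assay compound 2 gives > 23000 nM, also a limit. All three values sit at the same limit (the limit of > 23000 nM in this assay, at which 3 of the 3 values shown sit), so compound 3 cannot be placed relative to compound 1 or compound 2 on the numbers shown. The steps a step that the two limits leave unreadable from compound 1 to compound 3 and a step that the two limits leave unreadable from compound 2 to compound 3 are accordingly unreadable, as is a step that the two limits leave unreadable from compound 1 to compound 2.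

Compound 4 `COC(=O)c1ccc(NC(=O)[C@@H]2CC=C(CCC=C(C)C)C[C@H]2c2ccccc2)cc1` differs from compound 3 by 4-(methoxycarbonyl)phenyl in place of hydrogen on an amide-type nitrogen. For the measured compounds named here, the nearest comparison is compound 1, where an aryl group on the same nitrogen also left the value at the limit; no measured step in this set shows a change beyond the scatter in either direction. The expected step that the limit leaves unreadable from compound 3 to compound 4 is therefore none beyond the scatter. Compound 4 is expected to give 30000 nM in this assay, with a range from 10000 nM to 100000 nM, and most likely to be reported as a limit once more.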

Compound 4, inhibition constant: > 23000 nM
Compound 4: no number, only a limit (the forecaster's own chance of this, stated with the estimate: 85%); the middle value is on the limit's open side.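

Compound 4 adds no readable step against compound 1, compound 2 or compound 3 in this assay, because each value is a limit of the assay and not a number: the limit of > 23000 nM in this assay, at which 4 of the 4 values shown sit.

The compounds shown leave open whether any group on the amide nitrogen of the shared core gives a measurable inhibition constant, and how these four compounds rank.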